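The source may report more compounds than this note shows. Statements on the series, on what has been measured and on what is new or still open speak of the compounds shown alone.

Compound 1, with the structure `COC(=O)[C@@]1(C)C[C@@H](c2coc3ccc(Br)cc3c2=O)N(c2ccccc2)O1`, was tested in a functional assay on A549 cells (Homo sapiens) for inhibition, read by sulforhodamine B assay, with a stated time of 48 h (a lower number here means a stronger inhibitor, a higher number a weaker inhibitor), where compound 1 gives 9900 nM. Two further compounds carry a different core. Compound 3, with the structure `O=c1c([C@@H]2C[C@H](c3ccccc3)ON2c2ccccc2)coc2ccc(Br)cc12`, gives 51000 nM in this assay, and compound 2, with the structure `O=c1c([C@@H]2C[C@H](c3ccccc3)ON2c2ccccc2)coc2ccc(F)cc12`, gives 51500 nM. The difference between the core of compound 1 and the core of compound 3 is not broken down here; what the two values show is simply that compound 1 has the lower number of the pair. Compound 3 and compound 2 differ in only one place: fluoro in place of bromo on an aromatic carbon. That change produced a 1.0-fold higher number from compound 3 to compound 2 (0.00 log units; within the scatter), so swapping the two halogens left the result where it was.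

Compound 4, with the structure `COC(=O)[C@@]1(C)C[C@@H](c2coc3ccc(F)cc3c2=O)N(c2ccccc2)O1`, has not yet been measured. It relates to compound 1 exactly as compound 2 relates to compound 3: fluoro in place of bromo on an aromatic carbon. The place of the change is described in the same words in both cases, so this is the same change, carried out on the core of compound 1 rather than on the core of compound 3. Among the measured compounds shown here, only one example of the change has been measured, and a different core can in principle respond differently, so the expectation carries real uncertainty. Still, the expected step is a 1.0-fold higher number from compound 1 to compound 4 (0.00 log units; within the scatter), because a 1.0-fold higher number from compound 3 to compound 2 (0.00 log units; within the scatter) stayed within the scatter. Compound 4 is therefore expected to give 10000 nM in this assay, with a likely range from 4000 nM to 25000 nM.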

Compound 4, half-maximal inhibitory concentration: 20300 nM
For compound 4 the middle estimate is 2.0-fold (0.31 log units) below the measured one; measured number inside the range.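

In this assay, among the compounds shown here, fluoro in place of bromo on the core of compound 1 gives a 2.1-fold higher number from compound 1 to compound 4 (0.31 log units; beyond the scatter), a modest step that lies just beyond the usual scatter, whereas the same change on the other core gave no step that could be told from scatter. Set side by side, the two results cannot be told apart, so the swap behaves alike on both cores as far as these measurements can show: the same change on two cores in this assay, a 1.0-fold higher number (0.00 log units; within the scatter) from compound 3 to compound 2 and a 2.1-fold higher number (0.31 log units; beyond the scatter) from compound 1 to compound 4, 2.0-fold (0.31 log units) apart, within the scatter of two such steps. For the compounds shown here, this supports carrying the bromo-to-fluoro change from one core to the other as a small change at most, but it rests on only two pairs of compounds, so it does not prove that the two cores respond identically, nor does it establish that fluoro gives a higher number on the core of compound 1 alone.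

Still open is how other groups on the same aromatic carbon, such as chloro, methoxy or an amine, would behave on either core, as bromo and fluoro are the only groups shown there. Also open, as far as these compounds go, is how a carboxylic acid in place of the methyl ester of compound 1 would read in this assay.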